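The source may report more compounds than this note shows. Statements on the series, on what has been measured and on what is new or still open speak of the compounds shown alone.

Compound 1 `O=C(Nc1ccc(Oc2ccnc3[nH]ccc23)cc1)c1cc2cccnc2n(-c2ccc(C(F)(F)F)cc2Cl)c1=O`: 2160 nM
Compound 2 `COc1ccc(-n2c(=O)c(C(=O)Nc3ccc(Oc4ccnc5c4ccn5C)cc3)cc3cccnc32)cc1`: 2050 nM
Compound 3 `Cn1ccc2c(Oc3ccc(NC(=O)c4cc5cccnc5n(-c5ccc(C(F)(F)F)cc5Cl)c4=O)cc3)ccnc21`: 6050 nM

All three were measured in a functional assay on HT-29 cells (Homo sapiens) for antiproliferative activity, read by MTT assay, with a stated time of 72 h; a lower number here means a stronger inhibitor, a higher number a weaker inhibitor. Compound 3 gives the highest number of the three: the step of a 2.8-fold higher number from compound 1 to compound 3 (0.45 log units; beyond the scatter) and the step of a 3.0-fold higher number from compound 2 to compound 3 (0.47 log units; beyond the scatter) both lie beyond the scatter, so compound 3 is the weakest inhibitor of the measured set.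

Compound 4 `Cn1ccc2c(Oc3ccc(NC(=O)c4cc5cccnc5n(-c5ccc(C(F)(F)F)cc5Cl)c4=O)cc3F)ccnc21` differs from compound 3 in one place: fluoro in place of hydrogen on an aromatic carbon. Neither measured step bears on this change. Going by the values given here, one concerns methyl in place of hydrogen on an aromatic nitrogen, the other the aryl group on that nitrogen; no measured pair differs by a fluoro on an aromatic carbon. These data therefore give no ground for a step beyond the scatter in this assay in either direction, and the step of a 1.2-fold lower number from compound 3 to compound 4 (0.08 log units; within the scatter) is expected to be small. Compound 4 is accordingly estimated at 5000 nM in this assay, with a range from 2000 nM to 15000 nM.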

Compound 4, half-maximal inhibitory concentration: 5830 nM
The estimate for compound 4 lay 1.2-fold (0.07 log units) below the measured number; low and high end bracket the measured number.
By their numbers in this assay, from the lowest: compounds 2 and 1 (each within the scatter of the next); then compounds 4 and 3 (each within the scatter of the next).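

In this assay, fluoro in place of hydrogen on an aromatic carbon gives a 1.0-fold lower number from compound 3 to compound 4 (0.02 log units; within the scatter), so a single fluoro on this six-membered aromatic ring of carbon only, ortho to a large group and meta to a large group, produces no step beyond the scatter. Going by these compounds alone, the earlier compounds offered no pair differing on this ring, which makes this the first reading of a change there, and that reading is a flat one. No measurement given here speaks to why the number holds at this place.

As far as these compounds go, whether chloro, methoxy or an amine at the same carbon would also stay within the scatter remains open. From the compounds shown here alone, it is also open whether fluoro would read the same alongside the hydrogen on the aromatic nitrogen of compound 1 or the 4-methoxyphenyl group of compound 2.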